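Removing the thiocarbonyl side group from compound 3

A few compounds are considered here, and "the series" means these few. Any claim that something is new, unique, unknown or untested is made for them only; others in the source may bear on it.

Values in a functional assay on MCF7 cells (Homo sapiens) for antiproliferative activity, read by MTT assay, with a stated time of 96 h; on this read-out lower numbers stand for stronger inhibition and higher numbers for weaker inhibition:
- compound 1 `S=C(CN1CCCCC1)N/N=C1\CC2(CCCCC2)Oc2c1ccc1ccccc21` gives 11700 nM
- compound 2 `NCCCCCCC(=S)N/N=C1\CC2(CCCCC2)Oc2c1ccc1ccccc21` gives 4970 nM
- compound 3 `S=C(N/N=C1\CC2(CCCCC2)Oc2c1ccc1ccccc21)NC1CCCCC1` gives 15100 nM

Compound 3 carries the highest number of the three, but this does not set it apart from compound 1 (a 1.3-fold higher number from compound 1 to compound 3 (0.11 log units; within the scatter)). Only compound 2 is separated from it (a 3.0-fold higher number from compound 2 to compound 3 (0.48 log units; beyond the scatter)).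

The next structure is compound 4 `N/N=C1\CC2(CCCCC2)Oc2c1ccc1ccccc21`, which keeps the shared core and loses the whole side group (a hydrogen atom in place of a group of 9 heavy atoms (7 carbon, 1 nitrogen, 1 sulfur; one six-membered non-aromatic ring of carbon only), on an amine nitrogen).

Within the data shown here, three measured steps bear on this change, and all of them swap groups while the thiocarbonyl carbon stays in place. Besides the two above, there is the step between the other pair (a 2.4-fold lower number from compound 1 to compound 2 (0.37 log units; beyond the scatter)). Among the measured compounds shown here, these steps are small to modest, but no measured compound lacks the thiocarbonyl group, so they guide this larger change only loosely. The series gives no firm direction, and a move to a higher number seems slightly more likely than a move to a lower one. The expected step in this assay stays within the scatter (a 1.2-fold higher number from compound 3 to compound 4 (0.08 log units; within the scatter)), with a wide margin of doubt. Compound 4 is estimated at 18000 nM (expected range 6000 nM to 55000 nM).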

Compound 4, half-maximal inhibitory concentration: 9740 nM
The estimate for compound 4 lay 1.8-fold (0.27 log units) above the measured number; measured number inside the range.
By their numbers in this assay, from the lowest: compounds 2, 4, 1 and 3 (each within the scatter of the next, the first and the last beyond it).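

In this assay, replacing the whole side group with a hydrogen atom on the amine nitrogen gives no step beyond the scatter against any of the three compounds that carry the thiocarbonyl group (a 1.6-fold lower number from compound 3 to compound 4 (0.19 log units; within the scatter); a 1.2-fold lower number from compound 1 to compound 4 (0.08 log units; within the scatter); a 2.0-fold higher number from compound 2 to compound 4 (0.29 log units; within the scatter)). Across these four compounds, the number in this assay therefore does not require the thiocarbonyl group or any of its three substituents, and the shared core with only the amine nitrogen and its hydrogen stays level with compounds 1, 2 and 3 within the scatter. Among these compounds, the one gap beyond the scatter that remains among the side groups compared directly with compound 4 is the one between compound 2 and compound 3, and no measurement on hand explains the result for compound 4.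

The compounds shown leave open whether a carbonyl in place of the thiocarbonyl group would keep the same level. They also leave open whether the small edge of compound 2 belongs to its terminal amine, which a carboxylic acid at the chain end or a longer chain carrying the amine could test.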